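Ester group variation on the shared core: cytotoxicity notes

The compounds below may be only part of what the source reports. "The series", "measured", "known", "first", "only" and "open" are said of these compounds alone.

Compounds 1, 2 and 3 share one core and differ only in the ester group: compound 1 `CCC(=O)OCCc1c(-c2ccccc2Cl)c2cc(Cl)ccc2[nH]c1=O`, compound 2 `CCCCCCCC(=O)OCCc1c(-c2ccccc2Cl)c2cc(Cl)ccc2[nH]c1=O` and compound 3 `N#CCC(=O)OCCc1c(-c2ccccc2Cl)c2cc(Cl)ccc2[nH]c1=O`. In an ADME assay on HepG2 2.2.15 cells (Homo sapiens) for cytotoxicity (on this read-out lower numbers stand for higher toxicity in this test and higher numbers for lower toxicity in this test), compound 1 gives 95000 nM, compound 2 gives 78000 nM and compound 3 gives 100000 nM. Compound 2 holds the smallest of the three numbers, yet a 1.2-fold lower number from compound 1 to compound 2 (0.09 log units; within the scatter) and a 1.3-fold higher number from compound 2 to compound 3 (0.11 log units; within the scatter) both stay within the scatter. Compound 4 `O=C(CN1C(=O)c2ccccc2C1=O)OCCc1c(-c2ccccc2Cl)c2cc(Cl)ccc2[nH]c1=O` carries a group of 11 heavy atoms (8 carbon, 1 nitrogen, 2 oxygen; one five-membered non-aromatic ring with 1 hetero atom, one six-membered aromatic ring of carbon only) in place of a group of 6 heavy atoms (6 carbon; no ring), on a saturated chain carbon bound to a carbonyl carbon. The two earlier changes on a saturated chain carbon bound to a carbonyl carbon, a 1.1-fold higher number from compound 1 to compound 3 (0.02 log units; within the scatter) and a 1.3-fold higher number from compound 2 to compound 3 (0.11 log units; within the scatter), were flat, as was a 1.2-fold lower number from compound 1 to compound 2 (0.09 log units; within the scatter). For compound 4 the expected step is therefore a 1.1-fold higher number from compound 2 to compound 4 (0.04 log units; within the scatter), nothing beyond the scatter. Compound 4 is estimated at 85000 nM, within a range from 40000 nM to 170000 nM.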

Compound 4, half-maximal cytotoxic concentration: 960000 nM
Estimate against measurement, compound 4: 11-fold (1.05 log units) below, and the stated range ends below it.
By their numbers in this assay, from the lowest: compounds 2, 1 and 3 (each within the scatter of the next); then compound 4.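

This saturated chain carbon bound to a carbonyl carbon is not flat for every group: a 12-fold higher number from compound 2 to compound 4 (1.09 log units; beyond the scatter) and a 10-fold higher number from compound 1 to compound 4 (1.00 log units; beyond the scatter) and a 9.6-fold higher number from compound 3 to compound 4 (0.98 log units; beyond the scatter) all lie beyond the scatter in this assay and point to lower toxicity in this test. The group with two rings thus stands apart from the methyl, hexyl and cyano groups, which stayed within the scatter of one another. Nothing available here bears on this step.

Which part of the entering group carries the step remains open. A phenyl group or an amine on this carbon would help to separate the contributions of its two rings.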